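The compounds below may be only part of what the source reports. "The series", "measured", "known", "first", "only" and "open" are said of these compounds alone.

Compound 1 `CNC(=O)c1c(-c2ccc(F)cc2)oc2cc(-n3nccc3-c3ccc(B(O)O)c(F)c3)c(C3CC3)cc12` gives 10000 ng.h/mL in an ADME assay on the whole organism (Rattus norvegicus) for pharmacokinetics, read by LC-MS, at a dose of 5 mg/kg by the oral route; on this read-out lower numbers stand for lower exposure and higher numbers for higher exposure at the dose given.
Compound 2 `CNC(=O)c1c(-c2ccc(F)cc2)oc2cc(N(Cc3ccc(B(O)O)c(F)c3)S(C)(=O)=O)c(C3CC3)cc12` gives 700 ng.h/mL.
Compound 3 `CNC(=O)c1c(-c2ccc(F)cc2)oc2cc(N3C(=O)OC[C@@H]3c3ccc(B(O)O)c(F)c3)c(C3CC3)cc12` gives 280 ng.h/mL.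

Among these three, compound 2 stands second highest: compound 1 lies well above it and compound 3 lies below it, both gaps lying beyond the usual scatter. Compound 4 `CNC(=O)c1c(-c2ccc(F)cc2)oc2cc(N(C3CCc4c(B(O)O)cccc43)S(C)(=O)=O)c(C3CC3)cc12` differs from compound 2 in one place: a group of 12 heavy atoms (9 carbon, 1 boron, 2 oxygen; one five-membered non-aromatic ring of carbon only, one six-membered aromatic ring of carbon only) in place of a group of 11 heavy atoms (7 carbon, 1 boron, 2 oxygen, 1 fluorine; one six-membered aromatic ring of carbon only), on a sulfonamide nitrogen. Going by the values given here, no pair of measured compounds shows this change, so there is no measured step to lean on. The change is expected to leave exposure roughly where compound 2 stands, with the step of a 1.2-fold lower number from compound 2 to compound 4 (0.07 log units; within the scatter) expected to fall within the scatter. Compound 4 is therefore estimated at 600 ng.h/mL, in a range from 200 ng.h/mL to 1800 ng.h/mL.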

Compound 4, area under the concentration-time curve: 40 ng.h/mL
Beside the measured number, compound 4's estimate is 15-fold (1.18 log units) above it; measured number below the stated range.
By their numbers in this assay, from the lowest: compound 4; then compound 3; then compound 2; then compound 1.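

On the sulfonamide nitrogen, putting the group of 12 heavy atoms with its five-membered non-aromatic ring of carbon only in place of the group of 11 heavy atoms gives an 18-fold lower number from compound 2 to compound 4 (1.24 log units; beyond the scatter) in this assay. Exposure therefore depends strongly on the group carried at this place, even when the count of heavy atoms barely changes and the sulfonamide stays. No available measurement bears on the cause of this step.

The change also removes the fluorine, so the compounds shown cannot separate its loss from the added ring. As far as these compounds go, how an amine or a carboxylic acid on this group would read remains open.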